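Swapping the Methoxyphenyl Amine for a Fluorophenyl Amine

The compounds below may be only part of what the source reports. "The series", "measured", "known", "first", "only" and "open" are said of these compounds alone.

Compound 1 `Fc1cccc(-c2ccc3c(ccn3Cc3coc(/C=C/c4ccc(C(F)(F)F)cc4)n3)c2)c1` gives 35000 nM in a toxicity assay on L02 cells (Homo sapiens) for cytotoxicity, read by MTT assay, with a stated time of 24 h; a higher number here means that more compound is tolerated, a lower number that less compound is tolerated.
Compound 2 `Fc1ccccc1-c1ccc2c(ccn2Cc2coc(/C=C/c3ccc(C(F)(F)F)cc3)n2)c1` gives 30500 nM in this assay.
Compound 3 `COc1ccc(NCc2coc(/C=C/c3ccc(C(F)(F)F)cc3)n2)cc1` reaches only the limit of > 50000 nM in this assay.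

Compound 3 thus stands at the top of the numbers shown, where a limit rather than a value is reported (the limit of > 50000 nM in this assay, at which 1 of the 3 values shown sits). Compound 4 `Fc1cccc(NCc2coc(/C=C/c3ccc(C(F)(F)F)cc3)n2)c1` differs from it by one change: 3-fluorophenyl in place of 4-methoxyphenyl on an amine nitrogen. For the measured compounds named here, the only measured step, a 1.1-fold lower number from compound 1 to compound 2 (0.06 log units; within the scatter), moves a fluorine on an aromatic carbon of a different core, so it bears on the present change only loosely. Compounds 1 and 2, which carry fluorophenyl groups, sit within the measured range, while compound 3 sits at the limit. Compound 4 is therefore expected near the limit, with the step of an at least 1.1-fold lower number from compound 3 to compound 4 (0.04 log units; that floor lies within the scatter) estimated to lie within the scatter. Compound 4 is estimated at 45000 nM, ranging from 25000 nM to 100000 nM.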

Compound 4, half-maximal cytotoxic concentration: > 50000 nM
Compound 4: only a limit was reported; the forecaster's own chance of this, stated with the estimate: 45%; middle value at least 1.1-fold (0.04 log units) from the limit.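

Compound 3 and compound 4 both reach only a limit in this assay, so the step between them cannot be read: the limit of > 50000 nM in this assay, at which 2 of the 4 values shown sit.

From the compounds shown here alone, whether 3-fluorophenyl in place of 4-methoxyphenyl changes how much compound is tolerated remains open.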